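The source may report more compounds than this note shows. Statements on the series, on what has been measured and on what is new or still open speak of the compounds shown alone.

Measured compounds in a functional assay for antagonist activity at transient receptor potential cation channel subfamily V member 1 (Homo sapiens), read by FLIPR and calcium flux; a higher number here means a weaker inhibitor, a lower number a stronger inhibitor: compound 1 `O=C1COc2ccc(NC(=O)C3CCN(c4cccc(Br)c4)CC3)cc2N1` gives 330 nM. Compound 2 `Cc1cccc(N2CCC(C(=O)Nc3ccc4c(c3)NC(=O)CO4)CC2)c1` gives 490 nM. Compound 3 `CC(=O)N1CCc2cc(NC(=O)C3CCN(c4cccc(C(F)(F)F)c4)CC3)ccc21` gives only a limit, > 9000 nM.

Of the two numbers shown, compound 2 has the higher, yet the step of a 1.5-fold higher number from compound 1 to compound 2 (0.17 log units; within the scatter) leaves it and compound 1 within the scatter of each other. Compound 4 `O=C1COc2ccc(NC(=O)C3CCN(c4ccccc4C(F)(F)F)CC3)cc2N1` is not yet measured; the change from compound 2 is 2-(trifluoromethyl)phenyl in place of 3-methylphenyl on an amine nitrogen in a ring. For the measured compounds named here, no measured step bears directly on this change. Going by the values given here, the one step available, a 1.5-fold higher number from compound 1 to compound 2 (0.17 log units; within the scatter), alters the same position and is within the scatter. Compound 3 carries a trifluoromethyl on a different core and reaches only (the limit of > 9000 nM in this assay, at which 1 of the 3 values shown sits). A higher number beyond the scatter is expected in this assay, with the estimated step of a 2.4-fold higher number from compound 2 to compound 4 (0.39 log units; beyond the scatter). Compound 4 is expected at 1200 nM, within 350 nM to 4500 nM.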

Compound 4, half-maximal inhibitory concentration: 380 nM
For compound 4 the middle estimate is 3.2-fold (0.50 log units) above the measured one, within the range that was stated.
By their numbers in this assay, from the lowest: compounds 1, 4 and 2 (each within the scatter of the next). At a limit, above all of these: compound 3.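

In this assay, 2-(trifluoromethyl)phenyl on the amine nitrogen of the shared core is level with both earlier aryl groups, the steps being a 1.3-fold lower number from compound 2 to compound 4 (0.11 log units; within the scatter) and a 1.2-fold higher number from compound 1 to compound 4 (0.06 log units; within the scatter). This place therefore takes 10 heavy atoms in place of 7, and a different aryl substitution, with no step beyond the scatter. Compound 3 differs from these compounds in more than one place and remains a limit: the limit of > 9000 nM in this assay, at which 1 of the 4 values shown sits.

Still open, from the compounds shown here alone, is whether a carboxylic acid or an amine on this phenyl ring, or a cyclohexyl group in its place, would move the number beyond the scatter. Also open, going by these compounds, is how 2-(trifluoromethyl)phenyl reads on the core of compound 3.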